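The compounds below may be only part of what the source reports. "The series", "measured", "known", "first", "only" and "open" are said of these compounds alone.

Measured compounds in hand:

compound 1: `CO[C@@]12CCN(C)C[C@H]1[C@H](c1ccccc1)C(C#N)=C(N)O2` — 19800 nM
compound 2: `CO[C@@]12CCN(C)C[C@H]1[C@H](c1ccc(Cl)cc1)C(C#N)=C(N)O2` — 10500 nM

In a functional assay on trachea (Cavia porcellus) (a lower number here means a stronger inhibitor, a higher number a weaker inhibitor), compound 2 gives 10500 nM and is the lower of the two numbers recorded, while compound 1 gives 19800 nM. Going by the values given here, the single step between them, a 1.9-fold lower number from compound 1 to compound 2 (0.28 log units; within the scatter), stays within the scatter, so compound 2 and compound 1 cannot be told apart on this assay with confidence.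

Compound 3, `CO[C@@]12CCN(C)C[C@H]1[C@H](c1ccc(Cl)cc1Cl)C(C#N)=C(N)O2`, is the next member of the series. It differs from compound 2 by chloro in place of hydrogen on an aromatic carbon; the 4-chlorophenyl becomes 2,4-dichlorophenyl.

Among the compounds with values here, the only measured step that bears on this change is a 1.9-fold lower number from compound 1 to compound 2 (0.28 log units; within the scatter), the earlier chloro-for-hydrogen exchange on the same ring, and it produced no movement beyond the scatter. A second chloro on that ring is therefore expected to give, at most, a small step downward for compound 3 in this assay, with no change beyond the scatter the more likely outcome, so that the expected step is a 1.5-fold lower number from compound 2 to compound 3 (0.18 log units; within the scatter). On that basis compound 3 is estimated at 7000 nM, with a range from 2500 nM to 20000 nM.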

Compound 3, half-maximal inhibitory concentration: 14900 nM
Estimate against measurement, compound 3: 2.1-fold (0.33 log units) below; low and high end bracket the measured number.
By their numbers in this assay, from the lowest: compounds 2, 3 and 1 (each within the scatter of the next).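

In this assay, the chloro added on an aromatic carbon ortho to a large group and meta to a chloro group, turning 4-chlorophenyl into 2,4-dichlorophenyl, gives a 1.4-fold higher number from compound 2 to compound 3 (0.15 log units; within the scatter), so this position accepts a second chloro with no readable shift. Measured against the unsubstituted ring, 2,4-dichlorophenyl in place of phenyl gives a 1.3-fold lower number from compound 1 to compound 3 (0.12 log units; within the scatter), which shows that the two chloro groups together also stay inside the scatter, and the three compounds cannot be separated in this assay. No accompanying data bear on why this ring substitution leaves the number flat.

Still open is whether this flat response is limited to chloro, since the compounds shown do not say how an amine or a carboxylic acid on the same aromatic ring would read in this assay. Also open, on these data alone, is whether the other parts of the shared core are equally flat, for instance with a longer chain in place of the methyl on the ring nitrogen.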